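The compounds below may be only part of what the source reports. "The series", "measured", "known", "first", "only" and "open" are said of these compounds alone.

In a functional assay on HepG2 cells (Homo sapiens) for antiproliferative activity, read by CCK-8 assay, with a stated time of 48 h (on this read-out lower numbers stand for stronger inhibition and higher numbers for weaker inhibition), compound 3 `COc1ccc(/C=C\c2cc(OC)c(OC)c(OC)c2)cc1OCc1ccc(CNCCNC(C)=O)cc1` gives 6100 nM. Compound 2 `COc1ccc(/C=C\c2cc(OC)c(OC)c(OC)c2)cc1OCc1ccc(CNCCN(C)C)cc1` gives 4400 nM, and a 1.4-fold higher number from compound 2 to compound 3 (0.14 log units; within the scatter) leaves the two level. Compound 1 `COc1ccc(/C=C\c2cc(OC)c(OC)c(OC)c2)cc1OCc1ccc(CN2CCCC[C@H]2C(=O)O)cc1` reads > 10000 nM, which is a limit of the assay and not a number.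

Compound 4 `COc1ccc(/C=C\c2cc(OC)c(OC)c(OC)c2)cc1OCc1ccc(CN[C@H](C(=O)O)[C@@H](C)O)cc1` carries 1-carboxy-2-hydroxypropyl in place of 2-acetamidoethyl on an amine nitrogen. For the measured compounds named here, the nearest precedent is compound 1, the only measured compound with a carboxy-bearing group on its amine nitrogen, in the form of 2-carboxypiperidin-1-yl. Leaving that group gave an at least 2.2-fold lower number from compound 1 to compound 2 (0.35 log units; beyond the scatter) and an at least 1.6-fold lower number from compound 1 to compound 3 (0.21 log units; that floor lies within the scatter), so the sizes of both steps are floors rather than measured gaps. Bringing a carboxy group back is therefore expected to move this assay towards a higher number, and the reading may stop at the limit. The expected step is modest: a 2.0-fold higher number from compound 3 to compound 4 (0.29 log units; within the scatter). For compound 4 the estimated value is 12000 nM, with an expected range of 5000 nM to 30000 nM.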

Compound 4, half-maximal inhibitory concentration: > 10000 nM
Compound 4: only a limit was reported (the forecaster's own chance of this, stated with the estimate: 55%); the middle value lies beyond the limit too.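

In this assay compound 4 gives > 10000 nM, which is a limit and not a number. A carboxy-bearing group on this amine nitrogen now reaches the limit on an open chain, 1-carboxy-2-hydroxypropyl, as well as in the ring of 2-carboxypiperidin-1-yl, so the earlier single case has a second, and the two share one reading: the limit of > 10000 nM in this assay, at which 2 of the 4 values shown sit. The change gives an at least 2.2-fold higher number from compound 2 to compound 4 (0.35 log units; beyond the scatter) and an at least 1.6-fold higher number from compound 3 to compound 4 (0.21 log units; that floor lies within the scatter), both floors rather than measured gaps, and the step between the two compounds at the limit cannot be read.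

The compounds shown do not separate the carboxylic acid from the hydroxy group in compound 4. A methyl ester in its place, or a simple alkyl amine on the same nitrogen, would show whether the carboxylic acid alone tracks with the limit.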